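A few compounds are considered here, and "the series" means these few. Any claim that something is new, unique, unknown or untested is made for them only; others in the source may bear on it.

Measured in a functional assay on Caco-2 cells (Homo sapiens) for inhibition, read by MTT assay, with a stated time of 48 h; on this read-out higher numbers stand for weaker inhibition and lower numbers for stronger inhibition:
- Compound 1 `Fc1ccc(/C=N/Nc2nc(-c3cc(C(F)(F)F)cc(C(F)(F)F)c3)cs2)cc1F`: 62800 nM
- Compound 2 `COc1cc(/C=N/Nc2nc(-c3cccc(Br)c3)cs2)cc(Br)c1OC`: 43400 nM
- Compound 3 `Fc1ccc(/C=N/Nc2nc(-c3ccc(F)c(F)c3)cs2)cc1F`: 14200 nM

Compound 3 has the lowest of these three numbers, and its gap to each of the other two lies beyond the usual scatter. On this small set it therefore marks the strongest inhibition of Caco-2 cells seen so far, although all three numbers are high.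

The next compound is compound 4 `Fc1ccc(/C=N/Nc2nc(-c3ccccc3)cs2)cc1F`, which has phenyl in place of the 3,4-difluorophenyl of compound 3 on an aromatic carbon: phenyl in place of 3,4-difluorophenyl on an aromatic carbon. Among the compounds with values here, no step between measured compounds is available to scale this change, so any expectation for it rests on thin evidence.

With compound 3 at 14200 nM and the other two compounds well above it, a new value seems more likely to land somewhat higher than lower. The change itself is a small one, so no large move is expected. The estimated step is a 1.5-fold higher number from compound 3 to compound 4 (0.19 log units; within the scatter), which leans towards weaker inhibition but is not expected to go beyond the scatter.

For compound 4 the expected value is 22000 nM, with an estimated range from 8000 nM to 60000 nM.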

Compound 4, half-maximal inhibitory concentration: 20900 nM
Beside the measured number, compound 4's estimate is 1.1-fold (0.02 log units) above it; the measured number falls inside the stated range.
By their numbers in this assay, from the lowest: compounds 3 and 4 (each within the scatter of the next); then compounds 2 and 1 (each within the scatter of the next).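

Within the data shown here, compounds 3 and 4 form the first pair here that differs in one place, so the group on the aromatic carbon next to the ring nitrogen can be judged directly for the first time: in this assay, phenyl in place of 3,4-difluorophenyl gives a 1.5-fold higher number from compound 3 to compound 4 (0.17 log units; within the scatter). The fluorine atoms of the 3,4-difluorophenyl are therefore not needed at this position to keep the number within the scatter of compound 3, and the read-out does not separate these two groups, although this rests on a single pair. No measured information on these compounds bears on why the two groups read alike.

On these data alone, it remains open whether any group on this carbon can move the number beyond the scatter, for instance a phenyl carrying an amine or a carboxylic acid, or a longer chain such as n-butyl in place of the ring. As far as these compounds go, it is also open whether the same replacement would read alike with a different group in place of the 3,4-difluorophenyl that compounds 3 and 4 share.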